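From a Primary Amide to a Dimethylamide in CDK8 Binding

This account rests on a few compounds, and the source may have more. Where it says the series, first, only, none or still open, it means among the compounds named here.

Four compounds built on one shared core are compared. Compound 1, `O=C(O)/C=C/c1ccncc1-c1ccc2cc[nH]c2c1`, carries a carboxylic acid; compound 2, `NC(=O)/C=C/c1ccncc1-c1ccc2ccccc2c1`, carries a primary amide; compound 3, `COC1CN(C(=O)/C=C/c2ccncc2-c2ccc(F)cc2)C1`, carries an amide closed onto a small ring; and compound 4, `CN(C)C(=O)/C=C/c1ccncc1-c1ccc2ccccc2c1`, carries a dimethylamide.

Inhibition was measured in an assay on a protein complex for inhibition of CDK8/Cyclin C (Homo sapiens), with a stated time of 1 h; a higher number here means a weaker inhibitor, a lower number a stronger inhibitor. In this assay compound 1 gives 2.4 nM, and compound 2 gives 10.5 nM. Of the two numbers available, compound 2 stands at the higher one, and its gap to compound 1 lies beyond the usual scatter, so compound 1 is the stronger inhibitor of the two. In this assay compound 3 gives "not determined" (no result reported), so it cannot be placed.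

The move from compound 2 to compound 4 changes a single group: dimethylamino in place of amino on a carbonyl carbon. Within the data shown here, no measured pair shows this same change, so the expectation rests on compound 2 alone. The hydrogen-bond donor counted for compound 2 is lost in compound 4, and a small loss of potency is expected, with the step of a 1.9-fold higher number from compound 2 to compound 4 (0.28 log units; within the scatter) expected to stay close to the scatter rather than far beyond it. Compound 4 is therefore expected to give about 20 nM in this assay, within a range from 6 nM to 70 nM.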

Compound 4, half-maximal inhibitory concentration: 30.1 nM
For compound 4 the middle estimate is 1.5-fold (0.18 log units) below the measured one; measured number inside the range.
By their numbers in this assay, from the lowest: compound 1; then compound 2; then compound 4.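

In this assay, putting dimethylamino in place of amino on the carbonyl carbon gives a 2.9-fold higher number from compound 2 to compound 4 (0.46 log units; beyond the scatter) and so moves the number clearly, if modestly, past the usual scatter. Among these compounds, this is the first single-place comparison in the set, and it shows that this carbonyl carbon is not indifferent to what it carries, although compound 4 at 30.1 nM remains a measurable inhibitor after the hydrogen-bond donor counted on amino is gone. Nothing measured here gives a reason for the rise.

The change removes that donor and adds carbon atoms in the same step, so the two cannot be told apart from this pair; a methylamino group on the same carbonyl carbon, which keeps an amide hydrogen and carries a single methyl group, would bear directly on that question. Among the compounds shown here, how larger groups at this place would behave also stays open, whether a longer chain such as diethylamino or an amide closed onto a small ring like the one in compound 3, which has no number to place it.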